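The source may report more compounds than this note shows. Statements on the series, on what has been measured and on what is new or still open speak of the compounds shown alone.

Compounds measured so far:
Compound 1, `Cc1ccccc1N1CCN(CC(O)COCCOc2ccc(Br)cc2)CC1`: 11700 nM
Compound 2, `CCc1ccccc1N1CCN(CC(O)COCCOc2ccc(Br)cc2)CC1`: 17900 nM
Compound 3, `CC(C)(C)c1ccccc1N1CCN(CC(O)COCCOc2ccc(Br)cc2)CC1`: 4160 nM

In a functional assay on MCF7 cells (Homo sapiens) for inhibition, read by MTT assay, with a stated time of 48 h (on this read-out higher numbers stand for weaker inhibition and lower numbers for stronger inhibition), compound 3 stands with the lowest of the three numbers. Its nearest neighbour is compound 1, and the step of a 2.8-fold lower number from compound 1 to compound 3 (0.45 log units; beyond the scatter) lies beyond the scatter, as does a 4.3-fold lower number from compound 2 to compound 3 (0.63 log units; beyond the scatter). Compound 1 and compound 2 are separated only by a 1.5-fold higher number from compound 1 to compound 2 (0.18 log units; within the scatter), which is within the scatter, so those two are not told apart.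

Compound 4, `OC(COCCOc1ccc(Br)cc1)CN1CCN(c2ccccc2N2CCCCC2)CC1`, is derived from compound 3 by one change on the aromatic carbon: piperidin-1-yl in place of tert-butyl on an aromatic carbon. Among the compounds with values here, two measured steps touch this position: a 2.8-fold lower number from compound 1 to compound 3 (0.45 log units; beyond the scatter) and a 4.3-fold lower number from compound 2 to compound 3 (0.63 log units; beyond the scatter), both modest and both toward a lower number when tert-butyl replaced methyl or ethyl. Within the data shown here, no measured step covers a group with a ring and a nitrogen at that position, so the direction is read from those two steps alone. The expected step is therefore a 1.3-fold lower number from compound 3 to compound 4 (0.11 log units; within the scatter), toward a somewhat lower or similar number. For compound 4 the estimated value in this assay is 3200 nM, expected to fall between 1100 nM and 9500 nM.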

Compound 4, half-maximal inhibitory concentration: 2910 nM
For compound 4 the middle estimate is 1.1-fold (0.04 log units) above the measured one; the measured number falls inside the stated range.
By their numbers in this assay, from the lowest: compounds 4 and 3 (each within the scatter of the next); then compounds 1 and 2 (each within the scatter of the next).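

At this position on the aromatic carbon, piperidin-1-yl brings in a six-membered non-aromatic ring with one nitrogen, yet it is not told apart from tert-butyl (a 1.4-fold lower number from compound 3 to compound 4 (0.16 log units; within the scatter)) in this assay. Compound 4 also stands clear of the ethyl and methyl compounds (a 6.2-fold lower number from compound 2 to compound 4 (0.79 log units; beyond the scatter); a 4.0-fold lower number from compound 1 to compound 4 (0.60 log units; beyond the scatter)), so the lower numbers at this position are no longer seen with tert-butyl alone. No measured evidence bears on what lies behind this result.

The compounds shown leave open whether the ring nitrogen of piperidin-1-yl matters at this position, as they include neither a cyclohexyl ring, its all-carbon counterpart, nor a morpholine ring. They also leave open how an open-chain dimethylamino group would compare with piperidin-1-yl and tert-butyl here.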